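Cyclopropyl to Tert-Butyl: an Estimate for Compound 3

The compounds below may be only part of what the source reports. "The series", "measured", "known", "first", "only" and "open" are said of these compounds alone.

Going by the values given here, compound 2 `Cc1nc(C)n(CC(=O)N2CCN(c3sc(C(F)(F)F)nc3-c3cnc(C4CC4)nc3)C[C@H]2C)n1` gives 349 nM in a functional assay on U2OS cells for antagonist activity at C-X-C chemokine receptor type 3 (Homo sapiens), read by beta-arrestin recruitment (a lower number here means a stronger inhibitor, a higher number a weaker inhibitor), the higher of the two numbers measured so far, while compound 1 `Cc1nc(C)n(CC(=O)N2CCN(c3sc(C(F)(F)F)nc3-c3cnc(OC(C)C)nc3)C[C@H]2C)n1` gives 138 nM. Among the compounds with values here, the only measured step, a 2.5-fold higher number from compound 1 to compound 2 (0.40 log units; beyond the scatter), replaced isopropoxy with cyclopropyl. Compound 3 `Cc1nc(C)n(CC(=O)N2CCN(c3sc(C(F)(F)F)nc3-c3cnc(C(C)(C)C)nc3)C[C@H]2C)n1` carries the change further: tert-butyl in place of cyclopropyl on an aromatic carbon. Within the data shown here, no measured step covers tert-butyl itself, so the single guide is the modest size of a 2.5-fold higher number from compound 1 to compound 2 (0.40 log units; beyond the scatter). A step of similar size, or none beyond the scatter, is expected, estimated as a 1.2-fold higher number from compound 2 to compound 3 (0.08 log units; within the scatter). Compound 3 is therefore expected at 420 nM, within 160 nM to 1100 nM.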

Compound 3, half-maximal inhibitory concentration: 1030 nM
Beside the measured number, compound 3's estimate is 2.5-fold (0.39 log units) below it; the range from low to high includes it.
By their numbers in this assay, from the lowest: compound 1; then compound 2; then compound 3.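

In this assay, tert-butyl in place of cyclopropyl gives a 3.0-fold higher number from compound 2 to compound 3 (0.47 log units; beyond the scatter), so this position, between two ring nitrogen atoms, responds even when one all-carbon group replaces another. Tert-butyl in place of isopropoxy gives a 7.5-fold higher number from compound 1 to compound 3 (0.87 log units; beyond the scatter), the largest step among the three compounds. Nothing measured here accounts for either step.

The compounds shown leave open how a methoxy group, an amine or a plain methyl would read at this position. They also leave open whether the same order of isopropoxy, cyclopropyl and tert-butyl would hold on a different core.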